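The compounds below may be only part of what the source reports. "The series", "measured", "known", "first", "only" and "open" are said of these compounds alone.

Measured compounds:
- compound 1, `O=C(/N=C/c1ccc(Cl)cc1)Nc1ccc2c(c1)C(=O)C(=O)N2CN1CCCCC1`: 100 mg/kg
- compound 2, `O=C(/N=C/c1ccccc1Cl)Nc1ccc2c(c1)C(=O)C(=O)N2CN1CCCCC1`: 100 mg/kg

In a functional assay on the whole organism (strain Swiss albino) with Mus musculus as the target, with a stated time of 0.5 h (on this read-out higher numbers stand for an effect only at larger amounts of compound and lower numbers for an effect already at smaller amounts), compound 1 gives 100 mg/kg. Compound 2 gives 100 mg/kg, and the step of no change at the digits printed from compound 1 to compound 2 (within the scatter) shows that moving the chlorine to the other position left the minimum effective dose unchanged within the scatter. On the numbers shown, compound 1 therefore stands level with compound 2, and the pair gives no spread to work with.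

Compound 3, `O=C(/N=C/c1ccc(O)cc1)Nc1ccc2c(c1)C(=O)C(=O)N2CN1CCCCC1`, is not yet measured. Relative to compound 1 the change is hydroxy in place of chloro on an aromatic carbon. Among the measured compounds shown here, no measured step bears on this exchange: the only step available, no change at the digits printed from compound 1 to compound 2 (within the scatter), concerns a change of position of the same chloro group and was flat, so the series so far gives no evidence that substitution on this ring moves the read-out in either direction. With nothing pointing to a shift, the expectation for compound 3 in this assay is a step of about no change at the digits printed from compound 1 to compound 3 (within the scatter) from compound 1, that is, none beyond the scatter. The estimate for compound 3 is 100 mg/kg, with a range from 50 mg/kg to 300 mg/kg.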

Compound 3, minimum effective dose: 300 mg/kg
Beside the measured number, compound 3's estimate is 3.0-fold (0.48 log units) below it; measured number inside the range.
By their numbers in this assay, from the lowest: compounds 1 and 2 (each within the scatter of the next); then compound 3.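

In this assay, the aromatic ring carrying the chlorine is no longer a flat region of the series: a 3.0-fold higher number from compound 1 to compound 3 (0.48 log units; beyond the scatter) with hydroxy in place of chloro, so the identity of the group at this place matters even though moving the chlorine alone left the values level. The comparison with the other chlorinated compound points the same way, with a 3.0-fold higher number from compound 2 to compound 3 (0.48 log units; beyond the scatter) when 4-hydroxyphenyl stands in place of 2-chlorophenyl, so compound 3 needs a larger dose than either chlorinated compound, though the step remains modest. The data offer no measured basis for explaining this loss.

As far as these compounds go, whether an amine, a methoxy group or a carboxylic acid at this same place would stay level with compound 1 or move towards compound 3 remains open, and a single hydroxy compound cannot show whether the step is specific to hydroxy. The rest of the molecule is the same in all three compounds, so they also leave open how far changes elsewhere would shift the minimum effective dose.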